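The compounds below may be only part of what the source reports. "The series", "measured", "known", "first", "only" and "open" are said of these compounds alone.

Compound 1 `CNc1cc(Nc2cc(C)cc(C)c2)nn2c(C(=O)NCC(C)(C)CO)cnc12` is examined in an ADME assay on microsomes from liver (Mus musculus) for metabolic stability, read by mass spectrometry, with a stated time of 10 min, tested at 0.5 uM; on this read-out higher numbers stand for a more stable compound and lower numbers for a less stable compound; compound 1 gives 0%, the lowest of the three numbers in hand. Compound 3 `CNc1cc(Nc2cccc(C(C)(C)C)c2)nn2c(C(N)=O)cnc12` gives 3%, which lies within the scatter of compound 1. Compound 2 `CNc1cc(Nc2c(F)c(F)cc(F)c2F)nn2c(C(=O)NC[C@](C)(O)CO)cnc12` gives 26%, a gap from compound 1 that is beyond the scatter. For the measured compounds named here, compound 4 `CNc1cc(Nc2ccccc2OC)nn2c(C(=O)NCC(C)(C)CO)cnc12` is not yet measured in this assay; it differs from compound 1 in one place: 2-methoxyphenyl in place of 3,5-dimethylphenyl on a nitrogen on an aromatic ring No measured pair shares this change, so its effect has no precedent here. Because compound 1 gives 0%, the number can only hold or rise. The expected step is a number 6 percentage points higher from compound 1 to compound 4 (within the scatter), small and at the edge of the scatter. Compound 4 is estimated at 6% in this assay, between 0% and 20%.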

Compound 4, percent of the compound remaining: 2%
For compound 4 the middle estimate is 4 percentage points above the measured one; low and high end bracket the measured number.
By their numbers in this assay, from the lowest: compounds 1, 4 and 3 (each within the scatter of the next); then compound 2.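

In this assay, 2-methoxyphenyl in place of 3,5-dimethylphenyl on a nitrogen on an aromatic ring gives a number 2 percentage points higher from compound 1 to compound 4 (within the scatter). For the compounds shown here, this is the first single-place read at this position, and this change moves the number by no more than the scatter, with the rest of compound 1 held constant. No measured evidence bears on this result.

Still open, going by these compounds, is whether any group at this position can lift the number clear of the scatter. A pyridyl ring or a cyclohexyl group on the same nitrogen would test this.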